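A few compounds are considered here, and "the series" means these few. Any claim that something is new, unique, unknown or untested is made for them only; others in the source may bear on it.

Compound 1 `N#Cc1cn(C2OC(CO)CC2O)c2ncnc(N)c12` has the lowest of the three numbers given in a functional assay on KB cells (Homo sapiens) for inhibition (a higher number here means a weaker inhibitor, a lower number a stronger inhibitor), where compound 1 gives 4000 nM. Among the compounds with values here, compound 3 `NC(=S)c1cn([C@H]2C[C@H](O)[C@@H](CO)O2)c2ncnc(N)c12` gives 7000 nM in this assay, within the scatter of compound 1, while compound 2 `N#Cc1cn(C2CCC(CO)O2)c2ncnc(N)c12` gives 88000 nM; the only measured step, a 22-fold higher number from compound 1 to compound 2 (1.34 log units; beyond the scatter), concerns the sugar part and not the change considered here. Compound 4 `NC(=S)c1cn(C2OC(CO)CC2O)c2ncnc(N)c12` differs from compound 1 by a group of 3 heavy atoms (1 carbon, 1 nitrogen, 1 sulfur; no ring) in place of a group of 2 heavy atoms (1 carbon, 1 nitrogen; no ring), on an aromatic carbon. Compound 3 carries the same group on the same core, and its value sits within the scatter of compound 1, so no step beyond the scatter is expected, a 1.5-fold higher number from compound 1 to compound 4 (0.18 log units; within the scatter). Compound 4 is therefore estimated at 6000 nM in this assay, within the range 2500 nM to 15000 nM.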

Compound 4, half-maximal inhibitory concentration: 3000 nM
Estimate against measurement, compound 4: 2.0-fold (0.30 log units) above; the measured number falls inside the stated range.
By their numbers in this assay, from the lowest: compounds 4, 1 and 3 (each within the scatter of the next, the first and the last beyond it); then compound 2.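

In this assay, the direct pair shows that the cyano group and the group of 3 heavy atoms (1 carbon, 1 nitrogen, 1 sulfur; no ring) on this aromatic carbon cannot be told apart, with a 1.3-fold lower number from compound 1 to compound 4 (0.12 log units; within the scatter). The entering group carries a hydrogen-bond donor that cyano lacks, yet this difference comes with no step beyond the scatter. No measurement is available that would explain this result.

From the compounds shown here alone, whether an amine, a carboxylic acid or a longer chain on this carbon would give a similar number remains open. Also open, going by these compounds, is whether the two groups would still match on the sugar part of compound 2.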